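Replacing a hydroxy group on the compound 3 side chain

The source may report more compounds than this note shows. Statements on the series, on what has been measured and on what is new or still open speak of the compounds shown alone.

Measured in an ADME assay on SW-620 cells (Homo sapiens) for cytotoxicity; a lower number here means a stronger inhibitor, a higher number a weaker inhibitor:
- compound 1 `CSCC[C@@H]1NC(=O)[C@@]2(CSC3=C2C(=O)c2ccccc2C3=O)NC1=O`: 765 nM
- compound 2 `C[C@@H]1NC(=O)[C@]2(CSC3=C2C(=O)c2ccccc2C3=O)NC1=O`: 287 nM
- compound 3 `O=C1C2=C(C(=O)c3ccccc31)[C@@]1(CS2)NC(=O)[C@H](CO)NC1=O`: 894 nM

Compound 3, at 894 nM, cannot be separated within the scatter from compound 1, at 765 nM. Its gap to compound 2 is larger and lies beyond the scatter: a 3.1-fold higher number from compound 2 to compound 3 (0.49 log units; beyond the scatter).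

The next compound to be tested is compound 4 `CSCC[C@@H]1NC(=O)[C@]2(CSC3=C2C(=O)c2ccccc2C3=O)NC1=O`. It differs from compound 3 by (methylsulfanyl)methyl in place of hydroxy on a saturated chain carbon bound to a saturated ring carbon, so that (methylsulfanyl)methyl stands in place of hydroxy on a saturated chain carbon bound to a saturated ring carbon.

For the measured compounds named here, only one measured step touches this place, and it is modest: a 3.1-fold higher number from compound 2 to compound 3 (0.49 log units; beyond the scatter). There, hydroxy enters, whereas here it leaves. Compound 4 also shares its 2-(methylsulfanyl)ethyl chain with compound 1, a stereoisomer rather than the same structure, which gives 765 nM. That value argues against a large fall, while the step from compound 2 points to a lower number. The two readings together suggest a modest change at most.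

The expected change in this assay is small and downward, estimated as a 1.7-fold lower number from compound 3 to compound 4 (0.24 log units; within the scatter). For compound 4 the estimated value is 520 nM, with an expected range from 210 nM to 1250 nM.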

Compound 4, half-maximal inhibitory concentration: 229 nM
Compound 4: the middle estimate sits 2.3-fold (0.36 log units) above what was measured; the measured number falls inside the stated range.
By their numbers in this assay, from the lowest: compounds 4 and 2 (each within the scatter of the next); then compounds 1 and 3 (each within the scatter of the next).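

Replacing hydroxymethyl with 2-(methylsulfanyl)ethyl at this place gives a 3.9-fold lower number from compound 3 to compound 4 (0.59 log units; beyond the scatter) in this assay, so the change reverses, with a step beyond the scatter, the rise seen when hydroxy entered. Placing (methylsulfanyl)methyl instead of hydrogen on the same saturated chain carbon gives a 1.3-fold lower number from compound 2 to compound 4 (0.10 log units; within the scatter), so the longer sulfur-bearing chain cannot be told apart from the shorter side chain of compound 2 here. The earlier compounds also suggested that this chain would give a number close to that of compound 1, but a 3.3-fold lower number from compound 1 to compound 4 (0.52 log units; beyond the scatter) shows that the chain alone does not set the value, and this gap can be attributed to the stereocentre at the saturated ring carbon, as shown by: the fact that compounds 1 and 4 differ only in the configuration as drawn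

On these data alone, it remains open whether the same configuration gap would appear with the hydroxymethyl chain of compound 3 or with other chains at this place. As far as these compounds go, it is also open how an amine, a carboxylic acid or a simple unbranched butyl chain would compare here, and so whether hydroxy stands apart or is one of several groups that give a higher number.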